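Swapping Bromo for Trifluoromethyl on the Shared Core

The source may hold more compounds than are shown below. What is called first, only, known or untested is meant among the compounds shown, and "the series" means these compounds.

Measured in a functional assay on HeLa cells (Homo sapiens) for antiproliferative activity, read by MTT assay, with a stated time of 48 h; on this read-out lower numbers stand for stronger inhibition and higher numbers for weaker inhibition:
- Compound 1 `FC(F)(F)c1ccc2[nH]c(-c3cn(-c4ccccc4)nc3-c3ccccc3)nc2c1`: 1920 nM
- Compound 2 `FC(F)(F)c1ccc2[nH]c(-c3cn(-c4ccccc4)nc3-c3ccc(Cl)cc3)nc2c1`: 4420 nM
- Compound 3 `COc1ccc(-c2nn(-c3ccccc3)cc2-c2nc3cc(Br)ccc3[nH]2)cc1`: 1060 nM

Compound 3 gives 1060 nM, and this lies within the usual scatter of compound 1. Compound 2 gives the clearly higher number of 4420 nM.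

Compound 4 `COc1ccc(-c2nn(-c3ccccc3)cc2-c2nc3cc(C(F)(F)F)ccc3[nH]2)cc1` differs from compound 3 at one place: trifluoromethyl in place of bromo on an aromatic carbon. Trifluoromethyl stands in place of bromo on an aromatic carbon. Within the data shown here, no measured step makes this exchange. Among the measured compounds shown here, the only measured step, a 2.3-fold higher number from compound 1 to compound 2 (0.36 log units; beyond the scatter), is modest and beyond the scatter, but it is chloro in place of hydrogen, a different change, so it gives only a loose guide to size. Compound 1 already carries trifluoromethyl and gives 1920 nM, which suggests a small rise at most. No step beyond the scatter is therefore expected in this assay.

The expected change is a 1.4-fold higher number from compound 3 to compound 4 (0.15 log units; within the scatter).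

For compound 4 the estimated value is 1500 nM, with an expected range from 700 nM to 3300 nM.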

Compound 4, half-maximal inhibitory concentration: 2760 nM
Compound 4: the middle estimate sits 1.8-fold (0.26 log units) below what was measured; low and high end bracket the measured number.
By their numbers in this assay, from the lowest: compounds 3, 1, 4 and 2 (each within the scatter of the next, the first and the last beyond it).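

In this assay, among these compounds, this is the first direct reading of the exchange at this position: a 2.6-fold higher number from compound 3 to compound 4 (0.42 log units; beyond the scatter), so trifluoromethyl in place of bromo gives a modest loss of inhibition that goes beyond the scatter. With trifluoromethyl in place, the change on the other aromatic ring stays small, with a 1.4-fold higher number from compound 1 to compound 4 (0.16 log units; within the scatter) and a 1.6-fold lower number from compound 2 to compound 4 (0.20 log units; within the scatter), both within the scatter, so methoxy cannot be told apart from hydrogen or chloro here. Nothing given here accounts for the difference between bromo and trifluoromethyl.

Bromo appears only in compound 3, alongside methoxy, so it remains open whether its edge over trifluoromethyl would hold with hydrogen or chloro in that place. From the compounds shown here alone, how an amine or a carboxylic acid would read at this position also remains open.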